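Substituent swaps on the fused ring: compound 3 to compound 4

The source may hold more compounds than are shown below. What is called first, only, known or untested is meant among the compounds shown, and "the series" means these compounds.

Notes on the series. The parent is compound 1 `CC(C)(C)OC(=O)/C=C1/C(=O)Nc2ccccc21`; in a functional assay on OVCAR-3 cells (Homo sapiens) for inhibition, read by CCK-8 assay, with a stated time of 72 h, tested at 20 uM (a lower number here means less inhibition of growth, a higher number more inhibition of growth at the concentration tested), compound 1 gives 59.6%. Compound 2 `CCCCc1ccc2c(c1)/C(=C\C(=O)OC(C)(C)C)C(=O)N2` carries butyl on an aromatic carbon; in this assay compound 2 gives 60.2%, and the step of a number 0.6 percentage points higher from compound 1 to compound 2 (within the scatter) stays within the scatter. Compound 3 `COc1ccc2c(c1)/C(=C\C(=O)OC(C)(C)C)C(=O)N2` carries methoxy at the same place; in this assay compound 3 gives 59%. Compound 3 holds the lowest of the three numbers, but neither a number 0.6 percentage points lower from compound 1 to compound 3 (within the scatter) nor a number 1.2 percentage points lower from compound 2 to compound 3 (within the scatter) reaches beyond the scatter, so the three compounds cannot be separated on these data.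

The next change is chloro in place of methoxy on an aromatic carbon, giving compound 4 `CC(C)(C)OC(=O)/C=C1/C(=O)Nc2ccc(Cl)cc21`. Among the measured compounds shown here, no measured step introduces chloro, so the expectation rests on the neighbouring steps. Hydrogen, butyl and methoxy at this position all gave numbers within the scatter of one another, and on that basis compound 4 is expected to show no step beyond the scatter in this assay, the estimated step being no change at the digits printed from compound 3 to compound 4 (within the scatter). The estimate for compound 4 in this assay is 59%, with a range from 48% to 70%.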

Compound 4, percent growth inhibition at one concentration: 59.4%
Compound 4: the middle estimate sits 0.4 percentage points below what was measured; low and high end bracket the measured number.
By their numbers in this assay, from the lowest: compounds 3, 4, 1 and 2 (each within the scatter of the next).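

Chloro in place of methoxy gives a number 0.4 percentage points higher from compound 3 to compound 4 (within the scatter) in this assay and so removes the hydrogen-bond acceptor of methoxy from this aromatic carbon without a step beyond the scatter, which the earlier compounds could not show because hydrogen and butyl were the only comparisons for methoxy. Chloro also stays within the scatter of the other two groups at this position, with a number 0.8 percentage points lower from compound 2 to compound 4 (within the scatter) for the swap from butyl and a number 0.2 percentage points lower from compound 1 to compound 4 (within the scatter) for the swap from hydrogen, so the series now spans hydrogen, an alkyl chain, an ether and a halogen at one place with no separation among them. Compound 1, compound 2, compound 3 and compound 4 therefore form one group in this read-out at the concentration tested, and nothing on hand accounts for this flat result.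

As far as these compounds go, whether an amine or a carboxylic acid on the same aromatic carbon would give a step beyond the scatter remains open. Also open, from the compounds shown here alone, is whether these four compounds, alike at this single concentration, would separate across a range of concentrations.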